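Halogen swap on the sulfonamide aryl ring

The compounds below may be only part of what the source reports. "The series", "measured", "known", "first", "only" and "open" are said of these compounds alone.

Compound 1 `CCOC(=O)c1oc2ccc(NS(=O)(=O)c3ccc(Br)cc3)cc2c1C` is the reference point of the series. In a functional assay on HCT-116 cells (Homo sapiens) for inhibition, read by MTT assay, with a stated time of 72 h (a lower number here means a stronger inhibitor, a higher number a weaker inhibitor), compound 1 returns only the assay limit, > 40000 nM, a limit and not a number. Compound 2 `CCOC(=O)c1oc2ccc(NS(=O)(=O)c3ccc(C(F)(F)F)cc3)cc2c1C` carries trifluoromethyl in place of bromo; in this assay compound 2 gives 24200 nM. Among the compounds with values here, the only measured step, an at least 1.6-fold lower number from compound 1 to compound 2 (0.21 log units; that floor lies within the scatter), rests on (the limit of > 40000 nM in this assay, at which 1 of the 2 values shown sits), so its true size is not known. Compound 3 `CCOC(=O)c1oc2ccc(NS(=O)(=O)c3ccc(Cl)cc3)cc2c1C` differs from compound 1 by chloro in place of bromo on an aromatic carbon. Within the data shown here, no measured step covers this exchange, and the one step available started from a limit, so it gives no direction. For compound 3 a step of a number no higher from compound 1 to compound 3 (the limit leaves the size open) is expected, which is none beyond the scatter. Compound 3 is therefore estimated at 40000 nM, in the range 15000 nM to 100000 nM, with a fair chance that only a limit is reported again.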

Compound 3, half-maximal inhibitory concentration: > 40000 nM
Compound 3: no number, only a limit (the forecaster's own chance of this, stated with the estimate: 50%); the middle value sits exactly at the limit.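

In this assay compound 3 also returns only a limit, > 40000 nM, and not a number. Within the data shown here, with chloro as with bromo at this place no number is obtained, so the steps between limits cannot be read, and the only readable comparison is an at least 1.6-fold higher number from compound 2 to compound 3 (0.21 log units; that floor lies within the scatter), which leaves trifluoromethyl as the sole group here with a number but does not separate it from the halogens beyond the scatter. Most of what is known about this position therefore rests on a single boundary: the limit of > 40000 nM in this assay, at which 2 of the 3 values shown sit.

Going by these compounds, whether any group at this place lowers the number beyond the scatter remains open, for example an amine or a carboxylic acid in place of the halogen. Also open, on these data alone, is whether a carboxylic acid or an amide in place of the ethyl ester on the shared core would give readable numbers for the chloro and bromo compounds.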